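A few compounds are considered here, and "the series" means these few. Any claim that something is new, unique, unknown or untested is made for them only; others in the source may bear on it.

Of the compounds shown here, three built on one shared core have been measured in an assay on CHO cells for displacement of a labelled ligand from adenosine receptor A3 (Homo sapiens), read by scintillation counting, tested at 10 uM; on this read-out higher numbers stand for more inhibition at the one concentration tested (going by the name of the read-out) and lower numbers for less inhibition. Compound 1 `CC(C)(C)c1csc(N)c1C(=O)c1ccc(Cl)cc1` gives 1% in this assay. Compound 2 `Cc1c(Br)sc(N)c1C(=O)c1ccc(Cl)cc1` gives 1% in this assay. Compound 3 `CC(C)(C)Cc1c(-c2cccc(F)c2F)sc(N)c1C(=O)c1ccc(Cl)cc1` gives 1% in this assay. On the numbers shown, compound 3 stands level with compounds 1 and 2 at the digits reported: its nearest neighbour is compound 1 and its furthest is compound 2, and in both cases the gap lies within the usual scatter of repeated measurements, so no order among the three can be read from these figures. All three sit at a level that means essentially no displacement of the labelled ligand at the single concentration tested.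

Compound 4 `Cc1cccc(-c2sc(N)c(C(=O)c3ccc(Cl)cc3)c2CC(C)(C)C)c1` has not yet been measured. It differs from compound 3 in one place:

3-methylphenyl in place of 2,3-difluorophenyl on an aromatic carbon

Among the compounds with values here, no step between two measured compounds has been recorded, so there is nothing to compare this change against directly. What the three measured compounds show is that different groups at the carbon next to the ring sulfur have so far left the read-out at the same low level. On that basis the step from compound 3 to compound 4 is expected to be a number 2 percentage points higher from compound 3 to compound 4 (within the scatter), that is, no change beyond the scatter. Compound 4 is estimated to give 3% in this assay, with a likely range from -8% to 15%.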

Compound 4, a percentage reported as inhibition, at one concentration (the size of the read-out at that concentration, not a potency): 1%
Compound 4: the middle estimate sits 2 percentage points above what was measured; measured number inside the range.
By their numbers in this assay, from the lowest: compounds 1, 2, 3 and 4 (each within the scatter of the next).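

In this assay, within the data shown here, placing 3-methylphenyl where 2,3-difluorophenyl stood, on the aromatic carbon next to the ring sulfur, gives no change at the digits printed from compound 3 to compound 4 (within the scatter) and so provides the first direct comparison at this position. With the neopentyl group held in place, exchanging these two phenyl groups leaves the read-out at the same low level, but a single-concentration result this low cannot show whether either compound is closer to displacing the labelled ligand. No measurement shown here offers an explanation for this flat step.

Among these compounds, only two substituted phenyl groups have been compared directly at this position, so it remains open whether a phenyl ring bearing a carboxylic acid or an aminomethyl group, or a different ring such as pyridine, would lift the read-out. Going by these compounds, it is also open whether a phenyl group here would behave the same way if the neopentyl group were replaced by a shorter chain such as ethyl, or if the 4-chlorophenyl group on the carbonyl were replaced by an unsubstituted phenyl group.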